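Compound 4: swapping the 4-chlorophenyl group

The compounds below may be only part of what the source reports. "The series", "measured", "known", "first", "only" and "open" are said of these compounds alone.

Measured in an ADME assay on BE(2)-C cells (Homo sapiens) for cytotoxicity, read by MTT assay, with a stated time of 20 h; a higher number here means that more compound is tolerated, a lower number that less compound is tolerated:
- compound 1 `O=C(NCc1ccncc1)C1CCN(C(=O)c2cc3ccccc3n2Cc2ccc(Cl)cc2)CC1` gives a limit, > 100000 nM
- compound 2 `Cn1cnc(CNC(=O)C2CCN(C(=O)c3cc4ccccc4n3Cc3ccc(Cl)cc3)CC2)c1` gives a limit, > 50000 nM
- compound 3 `CN(Cc1ccccc1)C(=O)C1CCN(C(=O)c2cc3ccccc3n2Cc2ccc(Cl)cc2)CC1` gives 87000 nM

Among the measured compounds shown here, compound 3 holds the only true number in the set, while compound 1 and compound 2 give limits only. Compound 4 `CN(Cc1ccccc1)C(=O)C1CCN(C(=O)c2cc3ccccc3n2Cc2ccncc2)CC1` has pyridin-4-yl in place of 4-chlorophenyl on a saturated chain carbon bound to an aromatic nitrogen.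

For the measured compounds named here, none of the measured steps changes this place, so they bear on it only loosely. Going by the values given here, the one step with a readable floor is an at least 1.1-fold lower number from compound 1 to compound 3 (0.06 log units; that floor lies within the scatter). Two others cannot be sized: a step that the two limits leave unreadable from compound 1 to compound 2 and a step that the limit leaves unreadable from compound 2 to compound 3. The expectation for this assay therefore rests on compound 3 at 87000 nM as the sole anchor, and no direction can be argued from the data. The expected outcome is a 1.0-fold higher number from compound 3 to compound 4 (0.01 log units; within the scatter), which means no shift beyond the scatter. A limit rather than a number would be no surprise. For compound 4 the estimated value is 90000 nM, with an expected range of 45000 nM to 180000 nM.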

Compound 4, half-maximal cytotoxic concentration: 80300 nM
Estimate against measurement, compound 4: 1.1-fold (0.05 log units) above; the range from low to high includes it.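

Compound 4 carries the first change shown at this place, on a saturated chain carbon bound to an aromatic nitrogen: in this assay, pyridin-4-yl in place of 4-chlorophenyl gives a 1.1-fold lower number from compound 3 to compound 4 (0.03 log units; within the scatter). Among the compounds shown here, this place therefore accepts the exchange of a carbon-only aromatic ring bearing chlorine for a ring with 1 hetero atom without a shift beyond the scatter, which the earlier steps could not show, as they all changed another place and were either unreadable or had only a floor within the scatter. No measured property shown here accounts for this outcome.

Still open, on these data alone, is whether the same holds for a carboxylic acid or a primary amine in place of 4-chlorobenzyl. Also open, as far as these compounds go, is whether the swap behaves alike with ((pyridin-4-yl)methyl)amino on the carbonyl carbon.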